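From a Piperazine to a Lactam on the Shared Core

The source may hold more compounds than are shown below. What is called first, only, known or untested is meant among the compounds shown, and "the series" means these compounds.

Compound 1 `CC(C)N1CCN(c2ccc3c(c2)oc(=O)n3C(=O)NCCCCc2ccccc2)CC1` carries a 4-isopropylpiperazin-1-yl group on its core. In an assay on HEK293 cells for inhibition of acid ceramidase (Homo sapiens), read by fluorescence, with stated times of 10 min and 3 h (a lower number here means a stronger inhibitor, a higher number a weaker inhibitor), compound 1 gives 211 nM and sits second highest of the three numbers measured. Compound 2 `CC(=O)N1CCc2oc(=O)n(C(=O)NCCCCc3ccccc3)c2C1` gives 293 nM in this assay, a value within the scatter of that of compound 1. Compound 3 `CN1CCC(c2ccc3c(c2)oc(=O)n3C(=O)NCCCCc2ccc(F)cc2)CC1`, with a different saturated ring and a fluorine-bearing phenyl, gives 94 nM in this assay, a lower number than compound 1 by a step beyond the scatter. Compound 4 `CN1CCC(c2ccc3c(c2)oc(=O)n3C(=O)NCCCCc2ccccc2)CC1=O` has not yet been measured. It differs from compound 1 in one place: 1-methyl-2-oxopiperidin-4-yl in place of 4-isopropylpiperazin-1-yl on an aromatic carbon. For the measured compounds named here, no single-change step between measured compounds calibrates this exchange; compound 2, whose ring bears an acetyl group, and compound 3 lie on either side of compound 1 without isolating the ring change. A small step, in no firm direction, is therefore expected: a 1.2-fold higher number from compound 1 to compound 4 (0.07 log units; within the scatter). Compound 4 is estimated at 250 nM, with a range from 80 nM to 800 nM.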

Compound 4, half-maximal inhibitory concentration: 105 nM
The estimate for compound 4 lay 2.4-fold (0.38 log units) above the measured number; measured number inside the range.
By their numbers in this assay, from the lowest: compounds 3, 4, 1 and 2 (each within the scatter of the next, the first and the last beyond it).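

On an aromatic carbon of the shared core, this assay now has its first single-change reading, and 1-methyl-2-oxopiperidin-4-yl in place of 4-isopropylpiperazin-1-yl gives a 2.0-fold lower number from compound 1 to compound 4 (0.30 log units; within the scatter) with no step beyond the scatter. At this place, then, a six-membered non-aromatic ring with 2 hetero atoms and one with 1 hetero atom and a carbonyl are not told apart by this measurement, although the isopropyl group also leaves in the same exchange. No measurement shown here accounts for this result.

For the compounds shown here, the single step cannot separate the part played by the carbonyl from that of the ring nitrogen or the group on it. From the compounds shown here alone, whether a morpholine, an open-chain amine or a plain hydrogen at this place would stay within the scatter of compound 1 remains open.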